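The compounds below may be only part of what the source reports. "The series", "measured", "known", "first", "only" and "open" are said of these compounds alone.

Measured compounds:
compound 1, `Cc1cccc2cc(/C=C/C(=O)c3ccc(Cl)s3)c(Cl)nc12`: 116 nM
compound 2, `Cc1ccc2nc(Cl)c(/C=C/C(=O)c3ccc(Br)s3)cc2c1`: 88.4 nM
compound 3, `Cc1ccc2cc(/C=C/C(=O)c3ccc(I)s3)c(Cl)nc2c1`: 135 nM

All three were tested in a functional assay on HUVEC cells (Homo sapiens), read by BrdU incorporation, with a stated time of 72 h; on this read-out higher numbers stand for weaker inhibition and lower numbers for stronger inhibition. Compound 2 gives the lowest number of the three, yet its gap to compound 1 and its gap to compound 3 both lie within the scatter of repeated measurements, so no order among the three can be claimed.

Compound 4, `Cc1ccc2nc(Cl)c(/C=C/C(=O)c3sccc3Br)cc2c1`, is the next compound and has not been measured. It shares every atom with compound 2, joined differently: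
3-bromothiophen-2-yl in place of 5-bromothiophen-2-yl on a carbonyl carbon

Going by the values given here, no step between two measured compounds that differ in one place exists here, so there is no direct guide to the size of this change. The three measured compounds, which vary in the halogen on the thiophene and in the position of the methyl on the shared core, all sit close together, which suggests this series tolerates changes on the thiophene. The step from compound 2 to compound 4 is therefore expected to be small, possibly slightly toward weaker inhibition, and not clearly beyond the scatter in this assay. For compound 4 the estimate is 150 nM, with a range from 60 nM to 400 nM, which corresponds to an expected step of a 1.7-fold higher number from compound 2 to compound 4 (0.23 log units; within the scatter).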

Compound 4, half-maximal inhibitory concentration: 61.9 nM
For compound 4 the middle estimate is 2.4-fold (0.38 log units) above the measured one, and the stated range covers the measured number.
By their numbers in this assay, from the lowest: compounds 4, 2, 1 and 3 (each within the scatter of the next, the first and the last beyond it).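

In this assay, going by these compounds alone, the exchange of 5-bromothiophen-2-yl for 3-bromothiophen-2-yl on the carbonyl carbon gives a 1.4-fold lower number from compound 2 to compound 4 (0.15 log units; within the scatter) and is the first step that differs in one place only. It shows that the bromine can sit at either of these two places on the thiophene without the read-out telling compound 2 and compound 4 apart, so this change is tolerated on this core. No measurement shown here bears on why the two compounds read alike.

From the compounds shown here alone, whether an amine or a carboxylic acid in place of the bromine, or a phenyl ring in place of the thiophene, would be tolerated as well remains open. So does whether the same exchange would read alike on the core of compound 1.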